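Anilide for Acid in a Dithioester Chain Series

The compounds below may be only part of what the source reports. "The series", "measured", "known", "first", "only" and "open" are said of these compounds alone.

Measured so far, in a functional assay on NCI-H460 cells (Homo sapiens) for inhibition, read by MTT assay, with a stated time of 24 h, tested at 1 ug/mL; a lower number here means less inhibition of growth, a higher number more inhibition of growth at the concentration tested:
compound 1, `CC(=O)SCCC(CCCCC(=O)O)SC(C)=O`, gives 9.89%
compound 2, `O=C(O)CCCCC(CCSC(=O)c1ccccc1)SC(=O)c1ccccc1`, gives 0.77%
compound 3, `CC(=O)SCCC(CCCCC(=O)Nc1ccccc1)SC(C)=O`, gives 13.1%

The cores of compound 1 and compound 2 differ in more than one place, and the difference between the two cores is not broken down here. Compound 2 holds the lowest of the three numbers; its distance to compound 1 lies within the scatter, its distance to compound 3 beyond it.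

From compound 1 to compound 3 the change is anilino in place of hydroxy on a carbonyl carbon, and it made a number 3.2 percentage points higher from compound 1 to compound 3 (within the scatter).

Compound 4, `O=C(CCCCC(CCSC(=O)c1ccccc1)SC(=O)c1ccccc1)Nc1ccccc1`, carries the same change on compound 2: anilino in place of hydroxy on a carbonyl carbon. Because a number 3.2 percentage points higher from compound 1 to compound 3 (within the scatter) stayed within the scatter, the step for compound 4 is expected to be similar, a number 3.2 percentage points higher from compound 2 to compound 4 (within the scatter). Compound 4 is therefore estimated at 4%, between -6% and 14%.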

Compound 4, percent growth inhibition at one concentration: 5.93%
For compound 4 the middle estimate is 1.9 percentage points below the measured one; measured number inside the range.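

In this assay, anilino in place of hydroxy on a carbonyl carbon gave a number 5.2 percentage points higher from compound 2 to compound 4 (within the scatter). Set beside the earlier step, the change carried from one core to the other with no difference that can be told apart from scatter: the same change on two cores in this assay, a number 3.2 percentage points higher (within the scatter) from compound 1 to compound 3 and a number 5.2 percentage points higher (within the scatter) from compound 2 to compound 4, 2 percentage points apart, within the scatter of two such steps

This agreement does not show that the change has a real effect on either core, as both steps lie within the scatter, and two cores say nothing about a third.

The compounds shown leave open whether a benzylamino group, a simple alkyl amine amide or a chloro-substituted anilino group in place of anilino would give a step beyond the scatter. They also leave open what a longer chain would do.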